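The source may report more compounds than this note shows. Statements on the series, on what has been measured and on what is new or still open speak of the compounds shown alone.

In a functional assay on K-562R cells (Homo sapiens) for cytotoxicity, read by XTT assay, with a stated time of 24 h (a higher number here means a weaker inhibitor, a lower number a stronger inhibitor), compound 1 (`Cc1ccc(NC(=O)c2ccc(Br)cc2OCCCCn2ccnc2)cc1Nc1nccc(-c2cccnc2)n1`) gives 44600 nM, and compound 2 (`Cc1ccc(NC(=O)c2ccc(I)cc2OCCCCn2ccnc2)cc1Nc1nccc(-c2cccnc2)n1`), with iodo in place of bromo on an aromatic carbon, gives 51800 nM. These two values lie within the scatter of each other, so compound 2 cannot be ranked against compound 1.

Compound 3 (`COc1ccc(C(=O)Nc2ccc(C)c(Nc3nccc(-c4cccnc4)n3)c2)c(OCCCCn2ccnc2)c1`) keeps the shared core and the 4-(1H-imidazol-1-yl)butoxy group but has methoxy in place of iodo on an aromatic carbon. This carbon is meta to a 4-(1H-imidazol-1-yl)butoxy group and para to a large group.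

Among the compounds with values here, one measured step bears on this change. At the same carbon, the exchange of one halogen for another gave a 1.2-fold higher number from compound 1 to compound 2 (0.06 log units; within the scatter). Within the data shown here, that is thin evidence, since no compound with a methoxy group at this carbon has been measured. Even so, no step beyond the scatter is expected in this assay.

The expected change is a 1.1-fold lower number from compound 2 to compound 3 (0.05 log units; within the scatter). Compound 3 is therefore estimated at 46000 nM, with an expected range of 22000 nM to 95000 nM.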

Compound 3, half-maximal inhibitory concentration: 46600 nM
The estimate for compound 3 lay 1.0-fold (0.01 log units) below the measured number; measured number inside the range.
By their numbers in this assay, from the lowest: compounds 1, 3 and 2 (each within the scatter of the next).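

Within the data shown here, at the carbon para to a large group and meta to a 4-(1H-imidazol-1-yl)butoxy group, the earlier compounds showed only one halogen exchanged for another, whereas compound 3 places a different kind of group there. In this assay, methoxy in place of iodo gives a 1.1-fold lower number from compound 2 to compound 3 (0.05 log units; within the scatter) and methoxy in place of bromo gives a 1.0-fold higher number from compound 1 to compound 3 (0.02 log units; within the scatter), so all three compounds lie within the scatter of one another and cannot be ranked, even though the methoxy group counts one hydrogen-bond acceptor and the halogens none. Nothing on hand explains why these three numbers stay so close.

Going by these compounds, it remains open whether the number would stay within the scatter with a group of another kind at this carbon, such as an amine, a carboxylic acid or a longer chain like butoxy. The three compounds also cannot show whether a plain hydrogen at this carbon would give a similar number, or whether any group here can move the result beyond the scatter at all.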